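The source may report more compounds than this note shows. Statements on the series, on what has been measured and on what is new or still open speak of the compounds shown alone.

Measured so far in a functional assay on CCRF-CEM cells (Homo sapiens) for antiproliferative activity, read by fluorescence and resazurin assay, with a stated time of 48 h; a higher number here means a weaker inhibitor, a lower number a stronger inhibitor:
compound 1, `O=C(N/N=C/c1ccncc1)c1cc2cc([N+](=O)[O-])ccc2oc1=O`: 13000 nM
compound 2, `CCOc1ccc(NC(=O)c2cc3cc([N+](=O)[O-])ccc3oc2=O)cc1`: 13200 nM
compound 3, `CCOc1ccc(NC(=O)c2cc3ccccc3oc2=O)cc1`: 17900 nM

Compound 1 and compound 2 carry different cores; the difference between the two cores is not broken down here, and their two values lie within the scatter of each other. Compound 3 is compound 2 with hydrogen in place of nitro on an aromatic carbon, and that change gave a 1.4-fold higher number from compound 2 to compound 3 (0.13 log units; within the scatter), a step within the scatter. Compound 4, `O=C(N/N=C/c1ccncc1)c1cc2ccccc2oc1=O`, has not yet been measured in this assay. Within the data shown here, it is compound 1 with hydrogen in place of nitro on an aromatic carbon, the same change at the same place as the one from compound 2 to compound 3. For compound 4 the expected step is a 1.4-fold higher number from compound 1 to compound 4 (0.14 log units; within the scatter), resting on the measured step of a 1.4-fold higher number from compound 2 to compound 3 (0.13 log units; within the scatter). Compound 4 is therefore estimated at 18000 nM, with the range 9000 nM to 36000 nM.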

Compound 4, half-maximal inhibitory concentration: 3110 nM
Compound 4: middle estimate off by 5.8-fold (0.76 log units), on the high side; measured number below the stated range.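

Replacing nitro with hydrogen gave a 4.2-fold lower number from compound 1 to compound 4 (0.62 log units; beyond the scatter) in this assay. The outcome of this change therefore depended on the core that carried it, and the step on one core could not be carried over to the other: the same change on two cores in this assay, a 1.4-fold higher number (0.13 log units; within the scatter) from compound 2 to compound 3 and a 4.2-fold lower number (0.62 log units; beyond the scatter) from compound 1 to compound 4, 5.7-fold (0.75 log units) apart, beyond the scatter of two such steps. This does not show why the two cores differ, and two pairs give no rule for any further core.

On these data alone, it remains open whether an amine or a chlorine atom at the same place would follow the same course as hydrogen on either core. As far as these compounds go, it also remains open which part of the structure that separates compound 1 from compound 2 decides the size and direction of the step.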